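Phenyl for Ethyl Exchange on Two Acid Ceramidase Inhibitor Cores

The compounds below may be only part of what the source reports. "The series", "measured", "known", "first", "only" and "open" are said of these compounds alone.

Measured compounds:
Compound 1, `O=C(NCCCCc1ccccc1)N1C(=O)c2ccccc2C1=O`: 2.4 nM
Compound 2, `O=C(NCCCCc1ccccc1)n1cnc2ccccc21`: 2.5 nM
Compound 3, `CCCCCCNC(=O)n1cnc2ccccc21`: 6.6 nM

Three compounds have been run in an assay on HEK293 cells for inhibition of acid ceramidase (Homo sapiens), read by fluorescence, with stated times of 30 min and 1 h; on this read-out lower numbers stand for stronger inhibition and higher numbers for weaker inhibition. In this assay compound 1 gives 2.4 nM and compound 2 gives 2.5 nM, two values that lie within the scatter of each other. Compound 3 gives 6.6 nM. Compound 3 arises from compound 2 by one change, (ethyl in place of phenyl on a saturated chain carbon, four bonds along the chain from an amide-type nitrogen), and the step of a 2.6-fold higher number from compound 2 to compound 3 (0.42 log units; beyond the scatter) is a modest loss that reaches beyond the scatter. Compounds 1 and 2 share the same side chain but carry different cores; the difference between the two cores is not broken down here.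

Compound 4, `CCCCCCNC(=O)N1C(=O)c2ccccc2C1=O`, is not yet measured. It relates to compound 1 in the same way that compound 3 relates to compound 2: ethyl in place of phenyl on a saturated chain carbon, four bonds along the chain from an amide-type nitrogen. The place of the change is described in the same words in both pairs, so this is the same change carried onto the core of compound 1. Going by the values given here, since compound 1 and compound 2 sit so close in this assay, the expectation rests on the single measured instance of the change, the step from compound 2 to compound 3. Compound 4 is expected to fall off from compound 1 by about that amount, a 2.6-fold higher number from compound 1 to compound 4 (0.42 log units; beyond the scatter), which would be a step of the same order as the measured one. The estimate for compound 4 in this assay is 6.3 nM, with a range from 3 nM to 13 nM. A single precedent is a thin base, so the range is kept wide.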

Compound 4, half-maximal inhibitory concentration in the acid ceramidase assay: 7 nM
Estimate against measurement, compound 4: 1.1-fold (0.05 log units) below, within the range that was stated.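

In the acid ceramidase assay, compound 1 gives 2.4 nM and compound 4 gives 7 nM. In the acid ceramidase assay, exchanging phenyl for ethyl on the core of compound 1 gives a 2.9-fold higher number from compound 1 to compound 4 (0.46 log units; beyond the scatter), and this step agrees with the one seen on the other core: the same change on two cores in the acid ceramidase assay, a 2.6-fold higher number (0.42 log units; beyond the scatter) from compound 2 to compound 3 and a 2.9-fold higher number (0.46 log units; beyond the scatter) from compound 1 to compound 4, 1.1-fold (0.04 log units) apart, within the scatter of two such steps

In these two pairs, then, the loss on going from phenyl to ethyl carries over from one core to the other with its size unchanged, although two pairs cannot show why this is so or whether it would hold on a third core. In a physicochemical assay for metabolic stability, read by HPLC, in phosphate buffer, at pH 7.4, tested at 10 uM (a lower number here means that the compound disappears faster, a higher number that the compound lasts longer), compound 1 gives 0.1 h and compound 4 gives 0.15 h. In the physicochemical assay, the same change gives a 1.5-fold higher number from compound 1 to compound 4 (0.18 log units; within the scatter), so the exchange shifts the half-life by no more than the scatter, a reading that rests on the core of compound 1 alone and says nothing about the other core.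

The compounds shown leave open how the chain would behave with other groups at its end, such as a cyclohexyl ring, an amine or a carboxylic acid, and whether a longer chain would change the size of the step. They also leave open whether a group other than phenyl or ethyl would shift the half-life beyond the scatter.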